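Swapping butyl for cyclopropyl on a triple-bonded carbon

A few compounds are considered here, and "the series" means these few. Any claim that something is new, unique, unknown or untested is made for them only; others in the source may bear on it.

In a functional assay on HL-60 cells (Homo sapiens) for antiproliferative activity, with a stated time of 72 h (a higher number here means a weaker inhibitor, a lower number a stronger inhibitor), compound 1 (`CCCC#Cc1cc([C@@H]2O[C@H](CO)[C@@H](O)[C@H]2O)n2ncnc(N)c12`) gives 200 nM and compound 2 (`CCCCC#Cc1cc([C@@H]2O[C@H](CO)[C@@H](O)[C@H]2O)n2ncnc(N)c12`) gives 400 nM. Among the measured compounds shown here, these are the only two numbers so far, and they lie within the usual scatter of each other, so compound 2 stands level with its single neighbour.

The next structure, compound 3 (`Nc1ncnn2c([C@@H]3O[C@H](CO)[C@@H](O)[C@H]3O)cc(C#CC3CC3)c12`), keeps the shared core and differs from compound 2 by cyclopropyl in place of butyl on a triple-bonded carbon. In short, this places cyclopropyl in place of butyl on a triple-bonded carbon.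

For the measured compounds named here, only one measured step bears on this change: a 2.0-fold higher number from compound 1 to compound 2 (0.30 log units; within the scatter). It put methyl in place of hydrogen on a saturated chain carbon, and it stayed within the scatter. That is a limited guide, since neither measured compound has a ring at this place. With no evidence for a real shift in either direction, no change beyond the scatter is expected in this assay. The expected step is a 1.3-fold lower number from compound 2 to compound 3 (0.12 log units; within the scatter). For compound 3 the estimated value is 300 nM, with an expected range from 90 nM to 1000 nM.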

Compound 3, half-maximal inhibitory concentration: 40 nM
The estimate for compound 3 lay 7.5-fold (0.88 log units) above the measured number, and the stated range ends above it.
By their numbers in this assay, from the lowest: compound 3; then compounds 1 and 2 (each within the scatter of the next).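

In this assay, this position on the triple-bonded carbon proves able to respond strongly to a change of group: cyclopropyl in place of butyl gives a 10-fold lower number from compound 2 to compound 3 (1.00 log units; beyond the scatter), and cyclopropyl in place of propyl gives a 5.0-fold lower number from compound 1 to compound 3 (0.70 log units; beyond the scatter). The earlier pair gave no hint of this, since the one open-chain change shown, a 2.0-fold higher number from compound 1 to compound 2 (0.30 log units; within the scatter), stayed within the scatter, whereas closing the group into a three-membered ring gives a step beyond it, even though cyclopropyl has fewer heavy atoms than butyl. Nothing available here shows why the ring gives a lower number than either open chain.

Whether this gain belongs to rings in general or to the three-membered ring alone stays open, as the compounds shown include no cyclobutyl or cyclopentyl group at this place, and no branched chain such as isopropyl that would separate branching from ring closure. As far as these compounds go, it also remains unknown how this position would respond to a group carrying an amine or a hydroxyl at the end of the triple bond.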